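Shortening the linker of a nitroaniline warhead fragment

A few compounds are considered here, and "the series" means these few. Any claim that something is new, unique, unknown or untested is made for them only; others in the source may bear on it.

Measured compounds:
compound 1, `Cc1ncsc1-c1ccc(CNC(=O)[C@@H]2C[C@@H](O)CN2C(=O)[C@@H](NC(=O)COCCOCCOc2ccc(Cl)cc2C(=O)Nc2ccc([N+](=O)[O-])cc2Cl)C(C)(C)C)cc1`, 2370 nM
compound 2, `O=C(O)COCCOCCOc1ccc(Cl)cc1C(=O)Nc1ccc([N+](=O)[O-])cc1Cl`, > 10000 nM

These compounds were tested in a functional assay on LNCaP cells (Homo sapiens) for inhibition, read by WST assay, with a stated time of 3 days; a higher number here means a weaker inhibitor, a lower number a stronger inhibitor. Compound 1 is the full conjugate, and in this assay compound 1 gives 2370 nM. Compound 2 is the acid-capped linker fragment that carries the same nitroaniline part without the rest of compound 1. For compound 2 this assay reports only a limit, > 10000 nM, not a measured number, so compound 2 sits at the edge of what the assay can see, as marked by the limit of > 10000 nM in this assay, at which 1 of the 2 values shown sits.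

Compound 3, `C#CCCOc1ccc(Cl)cc1C(=O)Nc1ccc([N+](=O)[O-])cc1Cl`, has not yet been measured. It differs from compound 2 by ethynyl in place of 2-(carboxymethoxy)ethoxy on a saturated chain carbon, two bonds along the chain from an oxygen on an aromatic ring. The chain is cut short and the carboxylic acid is gone.

With compound 2 already at a limit, no direction can be read from a measured step. The change from compound 2 to compound 3 is expected to be small, an at least 1.1-fold lower number from compound 2 to compound 3 (0.04 log units; that floor lies within the scatter), and compound 3 is estimated at 9000 nM, within 2000 nM to 30000 nM.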

Compound 3, half-maximal inhibitory concentration: > 10000 nM
Compound 3: a limit, no number; the forecaster's own chance of this, stated with the estimate: 60%; middle value at least 1.1-fold (0.04 log units) away from the limit.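

In this assay compound 3 gives only a limit, > 10000 nM, not a measured number. Compound 2 also carries a limit, so no step between compound 2 and compound 3 can be read: the limit of > 10000 nM in this assay, at which 2 of the 3 values shown sit.

On these data alone, what stays open is whether compound 2 and compound 3 differ at all in this assay.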